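This account rests on a few compounds, and the source may have more. Where it says the series, first, only, none or still open, it means among the compounds named here.

Measured compounds in a functional assay on HEK293 cells for agonist activity at Bombesin receptor subtype-3 (Homo sapiens), read by luminescence and calcium flux, with a stated time of 10 min; a higher number here means that more compound is needed for the effect, a lower number that less compound is needed:
- compound 1, `CCC(C)(C)Cc1c[nH]c(CCc2ccc(-c3cnccn3)cc2)n1`: 100 nM
- compound 2, `CCC(C)(C)Cc1c[nH]c(CCc2ccc(-c3cccc(C#N)n3)cc2)n1`: 95 nM
- compound 3, `c1ccc(-c2ccc(CCc3nc(CC4CCCC4)c[nH]3)cc2)nc1`: 98 nM

Compound 2 gives the lowest number of the three in this assay, though the spread among the three is small: a 1.1-fold lower number from compound 1 to compound 2 (0.02 log units; within the scatter), and compound 3 sits beside compound 2 at a gap of the same order, so none of the three can be set apart from the others.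

Compound 4, `CCC(C)(C)Cc1c[nH]c(CCc2ccc(-n3cncn3)cc2)n1`, has not yet been measured. It differs from compound 2 in one place: 1H-1,2,4-triazol-1-yl in place of 6-cyanopyridin-2-yl on an aromatic carbon. Going by the values given here, the only measured step that touches the same place is that from compound 1 to compound 2, where one six-membered aromatic group on that carbon was exchanged for another: a 1.1-fold lower number from compound 1 to compound 2 (0.02 log units; within the scatter). Among the compounds with values here, no measured step exchanges a six-membered aromatic group for a five-membered one, so the bearing of the one known step is indirect; it shows only that this position has so far accepted a change of aromatic group without a step beyond the scatter. The expectation for compound 4 is therefore a small step in this assay, if any, with the wider uncertainty leaning toward a somewhat higher number: a 1.7-fold higher number from compound 2 to compound 4 (0.23 log units; within the scatter). Compound 4 is estimated at 160 nM, within a range of 50 nM to 600 nM.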

Compound 4, half-maximal effective concentration: 89 nM
For compound 4 the middle estimate is 1.8-fold (0.25 log units) above the measured one, within the range that was stated.
By their numbers in this assay, from the lowest: compounds 4, 2, 3 and 1 (each within the scatter of the next).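

In this assay, going by these compounds alone, a five-membered aromatic group now stands on this aromatic carbon, a change the earlier steps did not cover, and the size of the step stays small: a 1.1-fold lower number from compound 2 to compound 4 (0.03 log units; within the scatter) and a 1.1-fold lower number from compound 1 to compound 4 (0.05 log units; within the scatter). At this carbon, para to a large group, 1H-1,2,4-triazol-1-yl with 5 heavy atoms therefore serves in place of 6-cyanopyridin-2-yl with 8 heavy atoms or pyrazin-2-yl without a step beyond the scatter, and the nitrile is not needed for the number to hold among these compounds. Nothing at hand explains this flat response.

Still open, from the compounds shown here alone, is whether a non-aromatic group on this carbon, such as an amine or a carboxylic acid, would hold the number as well. Compound 3 differs from the others in more than one place, so the part played by the group on the far side of the shared core cannot be read.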